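The compounds below may be only part of what the source reports. "The series", "measured", "known", "first", "only" and "open" are said of these compounds alone.

Of the compounds shown here, two built on a shared core have been tested in an assay on tissue (M109 cells) for inhibition of Indoleamine 2,3-dioxygenase 1 (Mus musculus), with stated times of 2 h and 18 h; a lower number here means a stronger inhibitor, a higher number a weaker inhibitor. Compound 1 `C[C@@H](NC(=O)Nc1ccc(Cl)cc1)[C@H]1CC[C@@H](c2ccnc3ccc(F)cc32)CC1` gives 67 nM in this assay. Compound 2 `C[C@@H](NC(=O)c1cccc(Cl)c1)[C@H]1CC[C@@H](c2ccnc3ccc(F)cc32)CC1` gives 48 nM in this assay. Compound 2 has the lower of the two numbers, but the gap, a 1.4-fold lower number from compound 1 to compound 2 (0.14 log units; within the scatter), sits within the scatter, so the two cannot be put in order. Compound 3 `C[C@@H](NC(=O)c1ccccc1Cl)[C@H]1CC[C@@H](c2ccnc3ccc(F)cc32)CC1` has not been measured yet; it differs from compound 2 in one place: 2-chlorophenyl in place of 3-chlorophenyl on a carbonyl carbon. Within the data shown here, the only measured step, a 1.4-fold lower number from compound 1 to compound 2 (0.14 log units; within the scatter), replaced a (4-chlorophenyl)amino group with a 3-chlorophenyl group on a carbonyl carbon and stayed within the scatter. Among the measured compounds shown here, no measured step moves a chlorine within a phenyl ring, so the expectation rests on that one small step alone. The expected step in this assay is a 1.5-fold higher number from compound 2 to compound 3 (0.16 log units; within the scatter), nothing beyond the scatter. Compound 3 is estimated at 70 nM, with a range from 25 nM to 200 nM.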

Compound 3, half-maximal inhibitory concentration: 215 nM
Compound 3: middle estimate off by 3.1-fold (0.49 log units), on the low side; measured number above the stated range.
By their numbers in this assay, from the lowest: compounds 2 and 1 (each within the scatter of the next); then compound 3.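

In this assay, 2-chlorophenyl in place of 3-chlorophenyl on the carbonyl carbon gives a 4.5-fold higher number from compound 2 to compound 3 (0.65 log units; beyond the scatter) even though the two groups hold the same atoms, so the place of the chlorine on this phenyl ring can change the number beyond the scatter. The comparison with the amino-linked group gives a 3.2-fold higher number from compound 1 to compound 3 (0.51 log units; beyond the scatter) and so also lies beyond the scatter, unlike the step from compound 1 to compound 2, which stayed within it. No measurement at hand explains the difference between the two chlorophenyl groups.

Still open, as far as these compounds go, is where a 4-chlorophenyl group directly on the same carbonyl carbon would fall relative to compound 2 and compound 3. Also open, from the compounds shown here alone, is whether a plain phenyl ring, or a fluorine or methyl group in place of the chlorine, would give a similar number.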